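Moving a Methoxy Group Across a Benzyl Ring

This account rests on a few compounds, and the source may have more. Where it says the series, first, only, none or still open, it means among the compounds named here.

Of the compounds shown here, two built on a shared core have been tested in an assay on membranes from brain for displacement of a labelled ligand from Sigma non-opioid intracellular receptor 1 (Cavia porcellus), read by scintillation counting, with a stated time of 90 min; a higher number here means a weaker inhibitor, a lower number a stronger inhibitor. Compound 1 `COc1cccc(-n2cc(C(=O)NCCCCN3CCc4cc(OC)c(OC)cc4C3)nn2)c1` gives 20200 nM. Compound 2 `COc1cccc(Cn2cc(C(=O)NCCCCN3CCc4cc(OC)c(OC)cc4C3)nn2)c1` gives 12700 nM. Going by the values given here, the single step measured so far, a 1.6-fold lower number from compound 1 to compound 2 (0.20 log units; within the scatter), concerns a different kind of change from the one considered next. Among the compounds with values here, compound 2 holds one of these two numbers; its only neighbour is compound 1, whose number lies within the scatter of it, so no order between the two can be read from the data.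

Compound 3 `COc1ccc(Cn2cc(C(=O)NCCCCN3CCc4cc(OC)c(OC)cc4C3)nn2)cc1` is not yet measured. It differs from compound 2 by 4-methoxyphenyl in place of 3-methoxyphenyl on a saturated chain carbon bound to an aromatic nitrogen; the same difference, cut one bond further out, reads 3-methoxybenzyl to 4-methoxybenzyl. Within the data shown here, no measured step moves a methoxy group around this ring, so nothing in the numbers speaks for a shift in either direction. The expectation for compound 3 in this assay is therefore a value close to that of compound 2, with a 1.1-fold lower number from compound 2 to compound 3 (0.02 log units; within the scatter) expected to remain within the scatter. Compound 3 is estimated at 12000 nM, in a range from 5000 nM to 30000 nM.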

Compound 3, inhibition constant: 3350 nM
Estimate against measurement, compound 3: 3.6-fold (0.55 log units) above; measured number outside the range, below it.
By their numbers in this assay, from the lowest: compound 3; then compounds 2 and 1 (each within the scatter of the next).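

Within this assay, this is the first sign that the place of the methoxy group on the benzyl ring counts: 4-methoxyphenyl in place of 3-methoxyphenyl on a saturated chain carbon bound to an aromatic nitrogen gives a 3.8-fold lower number from compound 2 to compound 3 (0.58 log units; beyond the scatter) even though the two compounds hold the same atoms, joined differently. Going by these compounds alone, the one earlier step could not be read as a difference, whereas compound 3 also separates clearly from the other compound, with a 6.0-fold lower number from compound 1 to compound 3 (0.78 log units; beyond the scatter) as the larger of the two new steps, and so it has the lowest number of the three. The shift is real in the numbers, but no measurement at hand accounts for it.

As far as these compounds go, whether the lower number belongs to the methoxy group itself stays open, and a 4-hydroxybenzyl, a 4-chlorobenzyl or a plain benzyl group on the shared core would test that. Also open, from the compounds shown here alone, is whether the same move pays off with 4-methoxyphenyl directly on the aromatic nitrogen, or with a longer chain such as 4-methoxyphenethyl in that place.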